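Swapping Methoxy for Chloro in a Small Compound Set

The source may hold more compounds than are shown below. What is called first, only, known or untested is meant among the compounds shown, and "the series" means these compounds.

In a functional assay on U-87MG ATCC cells for antiproliferative activity against U-87 MG (Homo sapiens), read by MTT assay, with a stated time of 48 h (a lower number here means a stronger inhibitor, a higher number a weaker inhibitor), compound 1 `COc1ccc(-c2nc(C)c(C(=O)CSc3nc(-c4ccc(Cl)cc4)c(C#N)c(=O)[nH]3)s2)cc1` gives 45900 nM, and compound 2 `COc1ccc(-c2nc(C)c(C(=O)CSc3nc(-c4ccc(OC)cc4)c(C#N)c(=O)[nH]3)s2)cc1` gives 25300 nM. The difference between them is a 1.8-fold lower number from compound 1 to compound 2 (0.26 log units; within the scatter), so neither compound can be ranked ahead of the other, and compound 2 stands level with compound 1 in this assay.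

Compound 3 `COc1ccc(-c2nc(SCC(=O)c3sc(-c4ccc(Cl)cc4)nc3C)[nH]c(=O)c2C#N)cc1` departs from compound 2 by a single change, 4-methoxyphenyl to 4-chlorophenyl, with chloro in place of methoxy on an aromatic carbon. The change sits on a six-membered aromatic ring of carbon only, para to a large group, and this is not the ring that differs between compound 1 and compound 2.

For the measured compounds named here, only one measured step bears on it, the exchange of the same two groups in the opposite sense on that other ring, and its size is a 1.8-fold lower number from compound 1 to compound 2 (0.26 log units; within the scatter). Going by the values given here, with this as the sole guide, no step beyond the scatter is expected, and any drift would be toward a slightly higher number. The expected change is a 1.3-fold higher number from compound 2 to compound 3 (0.10 log units; within the scatter). For compound 3 the estimated value is 32000 nM, with an expected range of 13000 nM to 80000 nM.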

Compound 3, half-maximal inhibitory concentration: 35500 nM
The estimate for compound 3 lay 1.1-fold (0.05 log units) below the measured number; the range from low to high includes it.
By their numbers in this assay, from the lowest: compounds 2, 3 and 1 (each within the scatter of the next).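

In this assay the exchange on this ring gives a 1.4-fold higher number from compound 2 to compound 3 (0.15 log units; within the scatter) and so does not separate the two compounds: at this position, on a six-membered aromatic ring of carbon only and para to a large group, chloro and methoxy cannot be told apart by this read-out. The earlier pair showed the same for the other ring, where the step is a 1.8-fold lower number from compound 1 to compound 2 (0.26 log units; within the scatter) and likewise gives no ranking, so the exchange of these two groups has now been read on two different rings without a step beyond the scatter. No independent measurement is available here to account for this result.

The compounds shown leave open whether this position tolerates groups of a different kind, such as an amine, a carboxylic acid or a longer chain like butoxy, or whether one of these would produce a step beyond the scatter. They also leave open what the unsubstituted phenyl ring would give, and so whether chloro and methoxy contribute anything to the activity at this position at all.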